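A chloro-substituted biphenyl amide against the acid amidase

This account rests on a few compounds, and the source may have more. Where it says the series, first, only, none or still open, it means among the compounds named here.

The set holds two measured amides and one that awaits measurement. Compound 1 `O=C(CCCCCCc1cccc(F)c1)N1CCCC1` gives 7300 nM in an assay on HEK293 cells for inhibition of N-acylethanolamine-hydrolyzing acid amidase (Rattus norvegicus), read by LC-MS, with a stated time of 30 min; a lower number here means a stronger inhibitor, a higher number a weaker inhibitor. Compound 2 `Cc1ccccc1-c1ccc(CCC(=O)N2CCCC2)cc1` reaches only > 100000 nM in this assay, a limit of the assay rather than a number. The evidence the limit of > 100000 nM in this assay, at which 1 of the 2 values shown sits, tells where that limit stands among the values shown. Compound 3 `O=C(CCc1ccc(-c2cccc(Cl)c2)cc1)N1CCCC1` differs from compound 2 by 3-chlorophenyl in place of 2-methylphenyl on an aromatic carbon. For the measured compounds named here, no step between measured compounds is known, so the size and direction of the change in this assay can only be expected: the account foresees a step toward stronger inhibition, beyond the usual scatter, while allowing a real chance that compound 3 again sits at the limit. Compound 3 is estimated at 30000 nM, within 5000 nM to 100000 nM. This amounts to an expected step of an at least 3.3-fold lower number from compound 2 to compound 3 (0.52 log units; beyond the scatter).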

Compound 3, half-maximal inhibitory concentration: 25400 nM
Compound 3: the middle estimate sits 1.2-fold (0.07 log units) above what was measured; low and high end bracket the measured number.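

In this assay, for the compounds shown here, the change of 2-methylphenyl to 3-chlorophenyl gives an at least 3.9-fold lower number from compound 2 to compound 3 (0.59 log units; beyond the scatter), the first sign that the group at this position, para to a group of 9 heavy atoms, can move the reading even though the entering and leaving groups both hold 7 heavy atoms. The change brings compound 3 to a measurable number, so this series now has a readable response at this position. The value of compound 2 is a limit and not a number, so the step has a lower bound but no known full size: the limit of > 100000 nM in this assay, at which 1 of the 3 values shown sits.

The compounds shown leave open whether the chlorine or its place on the ring carries the step, which a 3-methylphenyl or 2-chlorophenyl group would separate. They also leave open how a longer chain would act alongside 3-chlorophenyl.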